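Dropping the Ethoxycarbonyl Group: From Compound 1 to Compound 4

The source may hold more compounds than are shown below. What is called first, only, known or untested is meant among the compounds shown, and "the series" means these compounds.

Three compounds have been measured so far:

compound 1, `CCOC(=O)c1ccc(NC(=O)N2CC2C#N)cc1`, giving 9700 nM
compound 2, `N#CC1CN1C(=O)NCc1ccccc1`, giving 10000 nM
compound 3, `N#CC1CN1C(=O)NC1CCCCC1`, giving 16000 nM

All three values come from a functional assay on L1210 cells (Mus musculus) for inhibition, read by MTT assay; a lower number here means a stronger inhibitor, a higher number a weaker inhibitor. Compound 1 holds the lowest of the three numbers, but its nearest neighbour, compound 2, sits a hair above it and even compound 3, the furthest, lies within the usual scatter of this kind of measurement. Among the measured compounds shown here, on these numbers, then, no compound can be called stronger or weaker than another; the three share one level.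

Compound 4, `N#CC1CN1C(=O)Nc1ccccc1`, has not been measured in this assay. It differs from compound 1 in a single place: hydrogen in place of ethoxycarbonyl on an aromatic carbon. For the measured compounds named here, nothing among the measured compounds tests this change directly, as no pair differs only there. What the set does show is that a benzyl group in compound 2 and a cyclohexyl group in compound 3 on the urea nitrogen give numbers close to that of compound 1, so the set looks insensitive to what sits on that side.

Compound 4 is therefore expected to show little or no step beyond the scatter, with the step of a 1.2-fold higher number from compound 1 to compound 4 (0.09 log units; within the scatter) estimated as essentially flat. The estimate for compound 4 in this assay is 12000 nM, with a range from 4000 nM to 40000 nM.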

Compound 4, half-maximal inhibitory concentration: 11000 nM
Estimate against measurement, compound 4: 1.1-fold (0.04 log units) above; low and high end bracket the measured number.
By their numbers in this assay, from the lowest: compounds 1, 2, 4 and 3 (each within the scatter of the next).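

In this assay, among the compounds shown here, this pair gives the first direct reading of this position: hydrogen in place of ethoxycarbonyl, on an aromatic carbon para to a group of 8 heavy atoms, gives a 1.1-fold higher number from compound 1 to compound 4 (0.05 log units; within the scatter). For the compounds shown here, the 5 heavy atoms of ethoxycarbonyl, including its 2 hydrogen-bond acceptors, can thus be removed from this ring with no difference that the measurement can separate from scatter, whereas the earlier compounds differed in the whole group on the urea nitrogen and could not isolate this change. No measured information on the compounds speaks to why this replacement leaves the number within the scatter.

Still open, on these data alone, is whether this position remains as flat with other groups on the same aromatic carbon, such as an amine, a carboxylic acid, a chlorine atom or a longer alkyl chain, since hydrogen and ethoxycarbonyl are only two of the possible substituents there. Also open is how far the numbers depend on the nitrile and the carbonyl of the shared core, as all the compounds shown carry both unchanged.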